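Bromoacrylamide series: replacing 4-bromophenyl with 3-methoxyphenyl

This account rests on a few compounds, and the source may have more. Where it says the series, first, only, none or still open, it means among the compounds named here.

compound 1 (`C=C(Br)C(=O)Nc1ccc(/C=C/C(=O)c2ccc(Cl)c(Cl)c2)cc1`): 3200 nM
compound 2 (`C=C(Br)C(=O)Nc1ccc(/C=C/C(=O)c2ccc(Br)cc2)cc1`): 1000 nM

Both values come from a functional assay on HeLa cells (Homo sapiens) for antiproliferative activity, with a stated time of 48 h (a higher number here means a weaker inhibitor, a lower number a stronger inhibitor), and compound 2 holds the lower of the two. Compound 3 (`C=C(Br)C(=O)Nc1ccc(/C=C/C(=O)c2cccc(OC)c2)cc1`) brings 3-methoxyphenyl in place of 4-bromophenyl on a carbonyl carbon with 3-methoxyphenyl in place of 4-bromophenyl on a carbonyl carbon. Going by the values given here, the one measured step at this place is a 3.2-fold lower number from compound 1 to compound 2 (0.51 log units; beyond the scatter) for a different pair of groups. Among the compounds with values here, no measured compound yet carries 3-methoxyphenyl, so the direction is uncertain. A modest move to a higher number is expected in this assay rather than a large one. The expected step is a 2.0-fold higher number from compound 2 to compound 3 (0.30 log units; within the scatter) by this estimate. Compound 3 is estimated at 2000 nM with an expected range from 700 nM to 6000 nM for now.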

Compound 3, half-maximal inhibitory concentration: 700 nM
For compound 3 the middle estimate is 2.9-fold (0.46 log units) above the measured one; measured number inside the range.
By their numbers in this assay, from the lowest: compounds 3 and 2 (each within the scatter of the next); then compound 1.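

In this assay the position on the carbonyl carbon takes 3-methoxyphenyl in place of 4-bromophenyl with a 1.4-fold lower number from compound 2 to compound 3 (0.15 log units; within the scatter), so a bromine on this ring is not required to hold the number. Going by these compounds alone, replacing 3,4-dichlorophenyl with 3-methoxyphenyl gives a 4.6-fold lower number from compound 1 to compound 3 (0.66 log units; beyond the scatter), which leaves 3,4-dichlorophenyl as the one group of the three that stands apart. Nothing available explains this difference.

Still open, on these data alone, is how an amine or a carboxylic acid on this ring would read, and whether 3-methoxyphenyl keeps its place when the bromoacrylamide is exchanged for a plain acrylamide.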